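One Aromatic Substituent Swapped at the End of a Chain

The compounds below may be only part of what the source reports. "The series", "measured", "known", "first", "only" and "open" are said of these compounds alone.

Among the compounds with values here, compound 2 `COc1cc(NC(C)CCCNC(=O)NNC(=O)Nc2ccc(Br)cc2)c2ncccc2c1` is one of three compounds measured so far in a functional assay on NCI-H460 cells (Homo sapiens) for inhibition, read by MTT assay, with a stated time of 72 h (on this read-out lower numbers stand for stronger inhibition and higher numbers for weaker inhibition), where compound 2 gives 27000 nM. That places compound 2 second highest of the three numbers. Its nearest neighbour is compound 1 `COc1cc(NC(C)CCCNC(=O)Nc2ccc(F)cc2)c2ncccc2c1`, which in this assay gives 26000 nM; the step of a 1.0-fold higher number from compound 1 to compound 2 (0.02 log units; within the scatter). Furthest away is compound 3 `COc1cc(NC(C)CCCNC(=O)Nc2ccc(O)cc2)c2ncccc2c1`, which in this assay gives 34000 nM; the step of a 1.3-fold higher number from compound 2 to compound 3 (0.10 log units; within the scatter). The remaining pair, a 1.3-fold higher number from compound 1 to compound 3 (0.12 log units; within the scatter), is also within the scatter, so the three measured compounds cannot be told apart on these numbers.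

Compound 4 `COc1cc(NC(C)CCCNC(=O)NNC(=O)Nc2ccc(C(F)(F)F)cc2)c2ncccc2c1` differs from compound 2 in one place: trifluoromethyl in place of bromo on an aromatic carbon. Within the data shown here, the most comparable measured step is the one from compound 1 to compound 3, which also exchanges one group on an aromatic carbon of the outer ring and stayed within the scatter; the two larger exchanges on the amide-type nitrogen did the same. On that basis no step beyond the scatter is expected, and the step of no change at the digits printed from compound 2 to compound 4 (within the scatter) is estimated to be small in either direction. For compound 4 the expected value in this assay is 27000 nM, with a range from 13000 nM to 55000 nM.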

Compound 4, half-maximal inhibitory concentration: 12000 nM
Compound 4: middle estimate off by 2.3-fold (0.35 log units), on the high side, and the stated range ends above it.
By their numbers in this assay, from the lowest: compound 4; then compounds 1, 2 and 3 (each within the scatter of the next).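

In this assay, within the data shown here, the exchange of bromo for trifluoromethyl gives a 2.3-fold lower number from compound 2 to compound 4 (0.35 log units; beyond the scatter) and is the first step in this set to pass beyond the scatter. It shows that this aromatic carbon, para to a large group, is a place where one substituent exchange can move the number, something the earlier exchange of fluoro for hydroxy could not show, as it gave a 1.3-fold higher number from compound 1 to compound 3 (0.12 log units; within the scatter) on a compound with a different link to the outer ring. What lies behind the step cannot be said, since no measurement shown here bears on its cause.

On these data alone, the two groups differ in more than one way, and with a single pair it stays open which difference matters, or whether a nitrile, a methyl group or an amine on the same carbon would move the number in the same direction. As far as these compounds go, it also stays open whether trifluoromethyl would produce a similar step of compound 1, where the 4-fluorophenyl group sits directly on the amide-type nitrogen.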